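Bromo in place of ethoxycarbonyl on a shared urea core

A few compounds are considered here, and "the series" means these few. Any claim that something is new, unique, unknown or untested is made for them only; others in the source may bear on it.

Measured so far:
compound 1, `Cc1ccc(NC(=O)N[C@@H](C)c2ccccc2)cc1`, 99%
compound 2, `CCCCCc1ccc(NC(=O)N[C@@H](C)c2ccccc2)cc1`, 98%
compound 3, `CCOC(=O)c1ccc(NC(=O)N[C@@H](C)c2ccccc2)cc1`, 97%

All three were tested in an ADME assay on the whole organism with Oryza sativa as the target, tested at 1 uM; a lower number here means a stronger effect, a higher number a weaker effect of the compound at the concentration tested. Compound 3 gives the lowest of the three numbers, but its nearest neighbour compound 2 and the furthest, compound 1, both lie within the scatter of it: a number 1 percentage points lower from compound 2 to compound 3 (within the scatter) and a number 2 percentage points lower from compound 1 to compound 3 (within the scatter). The step to the unmeasured compound 4, `C[C@H](NC(=O)Nc1ccc(Br)cc1)c1ccccc1`, is bromo in place of ethoxycarbonyl on an aromatic carbon. Among the compounds with values here, no measured step changes the same place in this way, and every measured step, including a number 1 percentage points lower from compound 1 to compound 2 (within the scatter), stays within the scatter. No step beyond the scatter is therefore expected in this assay, and no change at the digits printed from compound 3 to compound 4 (within the scatter) is the estimate. Compound 4 is expected to give about 97%, between 90% and 100%.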

Compound 4, a percentage reported as activity, at one concentration (the size of the read-out at that concentration, not a potency): 97%
Beside the measured number, compound 4's estimate shows no gap at the digits printed; low and high end bracket the measured number.
By their numbers in this assay, from the lowest: compounds 3, 4, 2 and 1 (each within the scatter of the next).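

In this assay, replacing the ethoxycarbonyl, with its two hydrogen-bond acceptors, by a single bromine atom with none leaves the number in place (no change at the digits printed from compound 3 to compound 4 (within the scatter)). Bromo also stays within the scatter of the two alkyl groups at this position (a number 1 percentage points lower from compound 2 to compound 4 (within the scatter); a number 2 percentage points lower from compound 1 to compound 4 (within the scatter)), so this aromatic carbon has now carried a halogen, an ester and alkyl chains with no step beyond the scatter. No measurement offers a reason for this. From the compounds shown here alone, whether an amine or a carboxylic acid here would move the number remains open, as do changes elsewhere on the shared core.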